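A Spiro Ring Replaces the Hydroxypyrrolidine in Compound 3

The compounds below may be only part of what the source reports. "The series", "measured", "known", "first", "only" and "open" are said of these compounds alone.

Of the compounds shown here, three sharing one core have been measured in an assay on brain for inhibition of Monoglyceride lipase (Mus musculus), with a stated time of 30 min; on this read-out higher numbers stand for weaker inhibition and lower numbers for stronger inhibition. Compound 1 `O=C(OC(C(F)(F)F)C(F)(F)F)N1CCN(Cc2ccc(C(F)(F)F)cc2N2CCCCC2)CC1` gives 130 nM in this assay. Compound 2 `O=C(OC(C(F)(F)F)C(F)(F)F)N1CCN(Cc2ccc(Cl)cc2N2CC[C@H]3CCCN3C2)CC1` gives 66 nM. Compound 3 `O=C(OC(C(F)(F)F)C(F)(F)F)N1CCN(Cc2ccc(C(F)(F)F)cc2N2CC[C@@H](O)C2)CC1` gives 8 nM, the lowest of the three numbers, with compound 2 nearest and compound 1 furthest, both gaps beyond the scatter.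

Compound 4 `O=C(OC(C(F)(F)F)C(F)(F)F)N1CCN(Cc2ccc(C(F)(F)F)cc2N2CCC3(CCOCC3)C2)CC1` has not yet been measured. It differs from compound 3 in one place: a group of 10 heavy atoms (8 carbon, 1 nitrogen, 1 oxygen; one five-membered non-aromatic ring with 1 hetero atom, one six-membered non-aromatic ring with 1 hetero atom) in place of a group of 6 heavy atoms (4 carbon, 1 nitrogen, 1 oxygen; one five-membered non-aromatic ring with 1 hetero atom), on an aromatic carbon. Among the compounds with values here, one measured step bears on this change, a 16-fold lower number from compound 1 to compound 3 (1.21 log units; beyond the scatter), a large movement that went with exchanging a ring without a hydrogen-bond donor for the 3-hydroxypyrrolidin-1-yl ring that has one. The entering group of compound 4 again carries no donor and is larger than either earlier ring, so a return toward the higher number of compound 1 is expected rather than a further gain. Compound 4 is therefore expected to show a step of a 5.0-fold higher number from compound 3 to compound 4 (0.70 log units; beyond the scatter) in this assay. Compound 4 is estimated at 40 nM, within 10 nM to 160 nM.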

Compound 4, half-maximal inhibitory concentration: 24 nM
The estimate for compound 4 lay 1.7-fold (0.22 log units) above the measured number; measured number inside the range.
By their numbers in this assay, from the lowest: compound 3; then compound 4; then compounds 2 and 1 (each within the scatter of the next).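

In this assay, the entering two-ring group gives a 3.0-fold higher number from compound 3 to compound 4 (0.48 log units; beyond the scatter), but also a 5.4-fold lower number from compound 1 to compound 4 (0.73 log units; beyond the scatter), so a group with no hydrogen-bond donor can still give a clearly lower number than the piperidin-1-yl ring at this aromatic carbon. The earlier 16-fold lower number from compound 1 to compound 3 (1.21 log units; beyond the scatter) could have been read as tied to the donor of the 3-hydroxypyrrolidin-1-yl ring, but compound 4 shows that a donor is not needed for a lower number than that of compound 1, and that a group of this larger size is accepted here. No measurement shown gives a reason for either step.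

The compounds shown leave open whether the oxygen of the entering group matters, as a cyclohexane ring in place of its six-membered ring would test. They also leave open where a 3-methoxypyrrolidin-1-yl group would fall relative to compound 3 and compound 4.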